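Acetyl to propanoyl on the amide of compound 1

The source may report more compounds than this note shows. Statements on the series, on what has been measured and on what is new or still open speak of the compounds shown alone.

Measured so far:
compound 1, `COc1ccc(CN(C(C)=O)c2cc(OC)c(OC)c(OC)c2)cc1O` — 270 nM
compound 2, `COc1ccc(CNc2cc(OC)c(OC)c(OC)c2)cc1Br` — 48100 nM

Of the two numbers in hand, compound 1 has the lower one. In a functional assay on HCT-116 cells (Homo sapiens) for inhibition, read by MTT assay, with a stated time of 48 h (a lower number here means a stronger inhibitor, a higher number a weaker inhibitor), compound 1 gives 270 nM, while compound 2, which differs from it at several places, gives 48100 nM; the gap between the two values lies well beyond the scatter, and compound 1 therefore stands as the stronger inhibitor of this pair.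

Compound 3, `CCC(=O)N(Cc1ccc(OC)c(O)c1)c1cc(OC)c(OC)c(OC)c1`, is not yet measured in this assay. It keeps the core of compound 1 and the amide, and differs from compound 1 only by methyl in place of hydrogen on a saturated chain carbon bound to a carbonyl carbon. Within the data shown here, no step between measured compounds of this kind is available, so the expectation rests on the size of the change alone: one carbon added to the chain on the carbonyl, with no new donor or acceptor. For compound 3 in this assay the estimated step of a 1.2-fold higher number from compound 1 to compound 3 (0.07 log units; within the scatter) is expected to fall within the usual scatter, in no firm direction. Compound 3 is expected to give about 320 nM, with a range from 120 nM to 850 nM.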

Compound 3, half-maximal inhibitory concentration: 61 nM
Beside the measured number, compound 3's estimate is 5.2-fold (0.72 log units) above it, and the stated range ends above it.
By their numbers in this assay, from the lowest: compound 3; then compound 1; then compound 2.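

In this assay, among these compounds, methyl in place of hydrogen on a saturated chain carbon bound to a carbonyl carbon gives a 4.4-fold lower number from compound 1 to compound 3 (0.65 log units; beyond the scatter) and is the first single-place step. The earlier compounds shown here could not isolate this position, since compound 1 and compound 2 differ at several places; this pair shows that the acyl chain on the amide is not fixed at acetyl, as propanoyl gives a modest but real move toward stronger inhibition in this cell assay. Nothing at hand accounts for the step, which remains a single observation from one pair of compounds.

Going by these compounds, it remains open whether the trend continues past propanoyl, as a longer chain such as butanoyl or pentanoyl could extend the gain, hold it or lose it, and a branched isopropyl or a cyclopropyl group on the carbonyl would test the shape of the chain rather than its length. An amine or a carboxylic acid at the end of the chain would show whether this position accepts a charged group as well as a plain alkyl chain.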